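This account rests on a few compounds, and the source may have more. Where it says the series, first, only, none or still open, it means among the compounds named here.

Working notes on the series.

The series is read in a functional assay on C6 cells (Rattus norvegicus) for cytotoxicity, read by MTT assay, with a stated time of 24 h, tested at 6 ug/mL; on this read-out lower numbers stand for a stronger effect and higher numbers for a weaker effect at the one concentration tested. Compound 1, `Cc1nnc(SCC(=O)N/N=c2/scc(-c3ccc(F)cc3)n2-c2ccccc2)s1`, gives 74.3% in this assay. Compound 2, `Cc1ccc(-c2cs/c(=N/NC(=O)CSc3ncccn3)n2-c2ccccc2)cc1`, gives 93.2% in this assay. For the measured compounds named here, compound 2 thus stands with the highest of the two numbers so far; the only other number, that of compound 1, lies lower by an amount beyond the usual scatter, so on this read-out compound 2 shows the weaker effect of the two.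

The next compound, compound 3, `O=C(CSc1ncccn1)N/N=c1/scc(-c2ccc(F)cc2)n1-c1ccccc1`, differs from compound 2 in one place: fluoro in place of methyl on an aromatic carbon. The change is small, a single heavy atom exchanged for another on the aromatic carbon named above, with no change in ring count, donors or acceptors.

Going by the values given here, no pair of measured compounds that differ only in this one place is available, so the size of the step cannot be read from the series itself. A modest move downward on the read-out, toward the region where compound 1 with its 74.3% stands, is expected, though a step within the scatter is also possible. Compound 3 is estimated to give 84% in this assay, between 68% and 98%, the expected step being a number 9.2 percentage points lower from compound 2 to compound 3 (within the scatter).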

Compound 3, a percentage reported as activity, at one concentration (the size of the read-out at that concentration, not a potency): 84%
For compound 3 middle estimate and measured number coincide at the digits printed; the range from low to high includes it.
By their numbers in this assay, from the lowest: compounds 1, 3 and 2 (each within the scatter of the next, the first and the last beyond it).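

In this assay, fluoro in place of methyl on an aromatic carbon, para to a large group, gives a number 9.2 percentage points lower from compound 2 to compound 3 (within the scatter), so this exchange on the six-membered aromatic ring of carbon only is not resolved from the usual scatter. For the compounds shown here, compound 3 also gives the first reading of a change on the sulfur: pyrimidin-2-yl in place of 5-methyl-1,3,4-thiadiazol-2-yl gives a number 9.7 percentage points higher from compound 1 to compound 3 (within the scatter), and this exchange is likewise not resolved from the scatter. Nothing at hand offers an explanation for either step.

Each exchange is read only once, so the compounds shown leave open whether the methyl-to-fluoro step would read the same with 5-methyl-1,3,4-thiadiazol-2-yl on the sulfur. They also leave open whether a larger change at either place would move the read-out beyond the scatter, such as an amine or a carboxylic acid in place of fluoro on the aromatic carbon, or a longer alkyl chain in place of pyrimidin-2-yl on the sulfur.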